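Hydroxy Added to the Seven-Membered Ring of a Cytotoxic Lactone

The source may report more compounds than this note shows. Statements on the series, on what has been measured and on what is new or still open speak of the compounds shown alone.

Going by the values given here, compound 1 `C=C1C(=O)O[C@@H]2[C@@H]1CC[C@H](C)[C@@](O)(C(=O)/C=C/C)[C@H]2OC(=O)/C(C)=C\C` gives 1.6 ug/mL in a functional assay on KB-V1 cells (Homo sapiens) for cytotoxicity, in the absence of a further agent (a lower number here means that less compound is needed, a higher number that more compound is needed for the effect), the highest of the two numbers so far, while compound 2 `C=C1C(=O)O[C@@H]2[C@@H]1C[C@@H](O)[C@H](C)[C@@](O)(C(=O)/C=C/C)[C@H]2OC(=O)/C(C)=C\C` gives 1.2 ug/mL in that assay, so that a 1.3-fold lower number from compound 1 to compound 2 (0.12 log units; within the scatter) stays within the scatter. Compound 3 `C=C1C(=O)O[C@@H]2[C@@H]1[C@@H](O)C[C@H](C)[C@@](O)(C(=O)/C=C/C)[C@H]2OC(=O)/C(C)=C\C` differs from compound 1 by hydroxy in place of hydrogen on a saturated ring carbon. Among the compounds with values here, the only measured step of the same kind, a 1.3-fold lower number from compound 1 to compound 2 (0.12 log units; within the scatter), also put a hydroxy on a saturated ring carbon of the shared core and moved the number no further than the scatter, so a step of similar size is expected, a 1.1-fold lower number from compound 1 to compound 3 (0.03 log units; within the scatter). Compound 3 is therefore estimated at 1.5 ug/mL, with a range from 0.8 ug/mL to 3 ug/mL.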

Compound 3, concentration for half-maximal effect: 3 ug/mL
The estimate for compound 3 lay 2.0-fold (0.30 log units) below the measured number, within the range that was stated.
By their numbers in this assay, from the lowest: compounds 2, 1 and 3 (each within the scatter of the next, the first and the last beyond it).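

In this assay, hydroxy in place of hydrogen on this saturated ring carbon, next to the ring atom that bears a fused ring, gives a 1.9-fold higher number from compound 1 to compound 3 (0.27 log units; within the scatter) and so stays within the scatter. With a 1.3-fold lower number from compound 1 to compound 2 (0.12 log units; within the scatter) as well, a hydroxy on either of these two saturated ring carbons leaves the number within the scatter of compound 1. Nothing available explains these results. The compounds shown leave open whether an amine, a methoxy group or a longer chain on this ring carbon would also stay within the scatter.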